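The source may hold more compounds than are shown below. What is called first, only, known or untested is meant among the compounds shown, and "the series" means these compounds.

Working notes on the series. Within the data shown here, compound 2 `CCOc1ccccc1C(=O)NCC1(N2CCN(CC)CC2)CCCCC1` stands lowest of the two values so far in an assay on HEK293 cells for inhibition of potassium/sodium hyperpolarization-activated cyclic nucleotide-gated channel 1 (Homo sapiens), with a stated time of 30 min; a lower number here means a stronger inhibitor, a higher number a weaker inhibitor; compound 2 gives 31.6 nM there, and compound 1 `CC(C)Oc1ccccc1C(=O)NCC1(N2CCN(C(C)C)CC2)CCCCC1` gives 251 nM, a gap beyond the scatter, though the two differ in two places and no single step is drawn between them. Compound 3 `CCOc1ccccc1C(=O)NCC1(N2CCN(C3CC3)CC2)CCCCC1` carries cyclopropyl in place of ethyl on an amine nitrogen in a ring. Among the measured compounds shown here, no measured step of this kind exists in the set, so the step from compound 2 to compound 3 is expected to be small, at most a modest weakening, as a 1.6-fold higher number from compound 2 to compound 3 (0.20 log units; within the scatter). Compound 3 is therefore expected at 50 nM, within 15 nM to 160 nM.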

Compound 3, half-maximal inhibitory concentration: 50.1 nM
Estimate against measurement, compound 3: 1.0-fold (0.00 log units) below; the measured number falls inside the stated range.
By their numbers in this assay, from the lowest: compounds 2 and 3 (each within the scatter of the next); then compound 1.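

Among these compounds, on the amine nitrogen in the ring, cyclopropyl in place of ethyl gives a 1.6-fold higher number from compound 2 to compound 3 (0.20 log units; within the scatter) in this assay, the first single-place step. Among the compounds shown here, this position therefore carries a three-membered carbon ring with a value that stays within the scatter of the ethyl compound, so ethyl is not the only group compatible with a value of this order here. No measurement bears on the origin of this step.

From the compounds shown here alone, whether a benzyl group, a hydroxyethyl chain or a longer alkyl chain on this nitrogen stays as close to compound 2 remains open. Also open, going by these compounds, is how a cyclobutyl ring would read at this position.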